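Adding a second methoxy to compound 2

The source may report more compounds than this note shows. Statements on the series, on what has been measured and on what is new or still open speak of the compounds shown alone.

Compound 1 `COc1cc(NC2=CC(=O)c3ncncc3C2=O)cc(OC)c1`: 7700 nM
Compound 2 `COc1cccc(NC2=CC(=O)c3ncncc3C2=O)c1`: 1800 nM
Compound 3 `O=C1C(Nc2cccc(B(O)O)c2)=CC(=O)c2ncncc21`: > 10000 nM, a limit of the assay

In a functional assay on MIA PaCa-2 cells (Homo sapiens) for cytotoxicity, read by MTT assay, with a stated time of 72 h (a higher number here means a weaker inhibitor, a lower number a stronger inhibitor), compound 2 gives 1800 nM, the lower of the two actual numbers. Compound 4 `COc1ccc(NC2=CC(=O)c3ncncc3C2=O)cc1OC` differs from it by methoxy in place of hydrogen, ortho to a methoxy group and para to a large group (methoxy in place of hydrogen on an aromatic carbon). The closest evidence is the opposite kind of change on another aromatic carbon, a 4.3-fold lower number from compound 1 to compound 2 (0.63 log units; beyond the scatter). The other measured step, an at least 5.5-fold higher number from compound 2 to compound 3 (0.74 log units; beyond the scatter), replaces the existing methoxy and bears on this change less directly. A weaker result is therefore expected, an estimated 2.1-fold higher number from compound 2 to compound 4 (0.32 log units; beyond the scatter). The expected value for compound 4 is 3800 nM, within an estimated range of 1300 nM to 9500 nM.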

Compound 4, half-maximal inhibitory concentration: 1800 nM
Estimate against measurement, compound 4: 2.1-fold (0.32 log units) above; measured number inside the range.
By their numbers in this assay, from the lowest: compounds 2 and 4 (each within the scatter of the next); then compound 1. At a limit, above all of these: compound 3.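

The methoxy group added ortho to a methoxy group and para to a large group is accommodated in this assay, with no change at the digits printed from compound 2 to compound 4 (within the scatter). The opposite change on another aromatic carbon gave a 4.3-fold lower number from compound 1 to compound 2 (0.63 log units; beyond the scatter), so across these compounds the effect of a second methoxy depends on which carbon carries it. Nothing measured here explains that difference.

On these data alone, whether this carbon would accept an amine or a carboxylic acid in place of methoxy remains open. So does whether a longer chain, such as ethoxy, would leave the number unchanged.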